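The source may report more compounds than this note shows. Statements on the series, on what has been measured and on what is new or still open speak of the compounds shown alone.

Compound 1 `FC(F)(F)c1ccc(CSc2nc(N3CCCCC3)c3ccccc3n2)cc1` stands at the edge of what a functional assay on HGC-27 cells (Homo sapiens) for cytotoxicity, read by MTT assay, with a stated time of 72 h (on this read-out lower numbers stand for stronger inhibition and higher numbers for weaker inhibition), can report: in this assay compound 1 returns > 50000 nM, which is a limit and not a number. Two measured relatives differ from it only at the aromatic carbon that carries the piperidin-1-yl group. Compound 2 `FC(F)(F)c1ccc(CSc2nc(Nc3ccccc3)c3ccccc3n2)cc1` carries an anilino group there and gives 26400 nM in this assay. Compound 3 `FC(F)(F)c1ccc(CSc2nc(Nc3ccccc3C(F)(F)F)c3ccccc3n2)cc1` carries a (2-(trifluoromethyl)phenyl)amino group there, and compound 3 reports > 50000 nM, again a limit. Among the measured steps, an at least 1.8-fold lower number from compound 1 to compound 2 (0.27 log units; that floor lies within the scatter), whereas an at least 1.8-fold higher number from compound 2 to compound 3 (0.27 log units; that floor lies within the scatter), and a step that the two limits leave unreadable from compound 1 to compound 3. Two of the three values sit at the limit of > 50000 nM in this assay, at which 2 of the 3 values shown sit, so little can be read with confidence. Compound 4 `Cc1ccccc1Nc1nc(SCc2ccc(C(F)(F)F)cc2)nc2ccccc12` arises from compound 1 through ((2-methylphenyl)amino in place of piperidin-1-yl on an aromatic carbon). The entering group shares the substituted phenylamino pattern of compound 3, with a methyl in place of its trifluoromethyl. Among the compounds with values here, the steps that bear on this change, from compound 1 onward to compound 2 and from compound 2 onward to compound 3, are both floors lying within the scatter, so no step beyond the scatter is expected in this assay. Compound 4 is therefore expected to give about 40000 nM, within 15000 nM to 100000 nM, with a real chance of a limit. The estimated step is an at least 1.2-fold lower number from compound 1 to compound 4 (0.09 log units; that floor lies within the scatter).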

Compound 4, half-maximal inhibitory concentration: 27500 nM
Compound 4: middle estimate off by 1.5-fold (0.16 log units), on the high side; measured number inside the range.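

In this assay, the (2-methylphenyl)amino group can now be set against the plain anilino group with two real numbers rather than a limit, and methyl in place of hydrogen gives a 1.0-fold higher number from compound 2 to compound 4 (0.02 log units; within the scatter). Against the groups whose compounds report only limits, the (2-methylphenyl)amino group gives an at least 1.8-fold lower number from compound 1 to compound 4 (0.25 log units; that floor lies within the scatter), and methyl in place of trifluoromethyl gives an at least 1.8-fold lower number from compound 3 to compound 4 (0.25 log units; that floor lies within the scatter), so neither floor leaves the scatter. Across the four compounds, therefore, no readable step at this aromatic carbon lies beyond the scatter, and the two floors rest on limits: the limit of > 50000 nM in this assay, at which 2 of the 4 values shown sit.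

The compounds shown leave open whether any other group at this aromatic carbon, such as morpholin-4-yl, benzylamino or a (2-methoxyphenyl)amino group, would move the number beyond the scatter. On these data alone, they also do not tell how far compound 1 and compound 3 lie past their limits, so the true size of the steps that touch these two compounds remains unknown.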